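A sulfur ring replaces an oxygen ring in compound 3

This account rests on a few compounds, and the source may have more. Where it says the series, first, only, none or still open, it means among the compounds named here.

In a functional assay on RS4-11 cells (Homo sapiens) for inhibition, read by CCK-8 assay, with a stated time of 72 h (on this read-out higher numbers stand for weaker inhibition and lower numbers for stronger inhibition), compound 1 (`CC1(C)CCC(CN2CCN(c3ccc(C(=O)NS(=O)(=O)c4ccc(OC5CCOCC5)c([N+](=O)[O-])c4)c(Oc4cnc5[nH]ccc5c4)c3)CC2)=C(c2ccc(C(F)(F)F)cc2)C1`) gives 375 nM and compound 2 (`CC1(C)CCC(CN2CCN(c3ccc(C(=O)NS(=O)(=O)c4ccc(OCC5CCCOC5)c([N+](=O)[O-])c4)c(Oc4cnc5[nH]ccc5c4)c3)CC2)=C(c2ccc(C(F)(F)F)cc2)C1`) gives 12 nM as the lower, stronger number of the two. Compound 3 (`CC1(C)CCC(CN2CCN(c3ccc(C(=O)NS(=O)(=O)c4ccc(OCC5CCSCC5)c([N+](=O)[O-])c4)c(Oc4cnc5[nH]ccc5c4)c3)CC2)=C(c2ccc(C(F)(F)F)cc2)C1`) is still unmeasured. Its difference from compound 2 is thian-4-yl in place of oxan-3-yl on a saturated chain carbon bound to an oxygen on an aromatic ring in one place: thian-4-yl in place of oxan-3-yl on a saturated chain carbon bound to an oxygen on an aromatic ring. Among the compounds with values here, the only measured step touching this part of the molecule is a 31-fold lower number from compound 1 to compound 2 (1.49 log units; beyond the scatter) and it is large, with (oxan-3-yl)methyl in place of oxan-4-yl. Within the data shown here, this part can therefore matter greatly, but no measured pair exchanges oxygen for sulfur in the ring, so there is no direct guide. Compound 3 keeps the saturated chain carbon of compound 2, so it is expected to sit closer to compound 2 at 12 nM than to compound 1 at 375 nM on this scale. In this assay the expected outcome is a 1.7-fold higher number from compound 2 to compound 3 (0.22 log units; within the scatter) as a small rise that does not clearly pass the scatter. For compound 3 the estimated value is 20 nM with 5 nM to 90 nM as its expected range.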

Compound 3, half-maximal inhibitory concentration: 15 nM
Beside the measured number, compound 3's estimate is 1.3-fold (0.12 log units) above it; low and high end bracket the measured number.
By their numbers in this assay, from the lowest: compounds 2 and 3 (each within the scatter of the next); then compound 1.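

In this assay, replacing oxan-3-yl with thian-4-yl on the saturated chain carbon changes both the ring's hetero atom and its point of attachment, yet the result, a 1.3-fold higher number from compound 2 to compound 3 (0.10 log units; within the scatter), stays within the scatter. The other new comparison, a 25-fold lower number from compound 1 to compound 3 (1.40 log units; beyond the scatter), shows that the large difference from compound 1 also appears with a second ring on the chain carbon, so among these compounds the low number does not depend on an oxan-3-yl ring or on oxygen in the ring. No measurement shown here explains these numbers or the closeness of compound 2 and compound 3.

The two changes in the step to compound 3 remain tied together, and a (oxan-4-yl)methyl or (thian-3-yl)methyl group would be needed to judge the hetero atom and the attachment point separately. On these data alone, how far this tolerance extends is also open, for example to a piperidine ring carrying an amine nitrogen, or to a longer chain such as a two-carbon ethyl link between the ring and the oxygen on the aromatic ring.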